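This account rests on a few compounds, and the source may have more. Where it says the series, first, only, none or still open, it means among the compounds named here.

Of the compounds shown here, three built on one shared core have been tested in an ADME assay on HFF cells (Homo sapiens) for cytotoxicity, with a stated time of 8 days; a higher number here means that more compound is tolerated, a lower number that less compound is tolerated. Compound 2 `Nc1nc(NC2CC2)c2ncn(/C=C3/CC3(CO)CO)c2n1` carries a cyclopropylamino group. In this assay compound 2 reaches only the limit of the measurement, > 300000 nM. Compound 1 `Nc1nc(NCc2ccccc2)c2ncn(/C=C3/CC3(CO)CO)c2n1` carries a benzyl group on the same nitrogen. In this assay compound 1 also stops at the limit, > 300000 nM. Compound 3 `Nc1nc2c(ncn2/C=C2/CC2(CO)CO)c(=O)[nH]1` is the third member of the set. In this assay compound 3 likewise gives only the limit, > 300000 nM. Among the measured compounds shown here, the one step that joins two of these, a step that the two limits leave unreadable from compound 1 to compound 2, cannot be read as a size, both ends sitting at the limit. The shared picture is the limit of > 300000 nM in this assay, at which 3 of the 3 values shown sit, so compound 2 stands at the limit alongside the other two, with no number to set it apart from them.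

Compound 4 `CCCCOc1nc(N)nc2c1ncn2/C=C1/CC1(CO)CO` differs from compound 2 in one place: butoxy in place of cyclopropylamino on an aromatic carbon. The single measured step offers no size to carry over, and every shown value rests at the limit. No direction is therefore expected, and any movement in this assay is expected to stay within the scatter. The step of a number no higher from compound 2 to compound 4 (the limit leaves the size open) is expected to be close to none. Compound 4 is estimated at 300000 nM, within a range from 150000 nM to 600000 nM, most likely reported once more as a limit.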

Compound 4, half-maximal cytotoxic concentration: > 300000 nM
Compound 4: no number, only a limit; the forecaster's own chance of this, stated with the estimate: 85%; the middle value sits exactly at the limit.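

Compound 4 gives only a limit, as do compound 1 and compound 2, so neither step to compound 4 can be read as a size. The picture is unchanged: the limit of > 300000 nM in this assay, at which 4 of the 4 values shown sit.

The compounds shown leave open how much compound the cells actually tolerate in this assay, and whether the group at this place makes any difference there.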